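A few compounds are considered here, and "the series" means these few. Any claim that something is new, unique, unknown or untested is made for them only; others in the source may bear on it.

Compound 3 `NC(=S)Nc1cccc(OCCCCCOc2cccc(Nc3ccccc3)c2)c1` gives 11000 nM in an ADME assay on Ava5 cells (Homo sapiens) for cytotoxicity (a lower number here means that less compound is tolerated, a higher number that more compound is tolerated), the lowest of the two numbers available; compound 2 `NC(=S)Nc1cccc(OCCCCCOc2cccc(Oc3ccccc3)c2)c1` is nearest with 18000 nM, and the step of a 1.6-fold lower number from compound 2 to compound 3 (0.21 log units; within the scatter) stays within the scatter. Compound 1 `NC(=S)Nc1cccc(OCCCCCOc2ccccc2)c1` reports only a limit, > 50000 nM (the limit of > 50000 nM in this assay, at which 1 of the 3 values shown sits). Compound 4 `NC(=S)Nc1cccc(OCCCCCOc2cccc(C(=O)c3ccccc3)c2)c1` carries the change (benzoyl in place of anilino on an aromatic carbon). Among the measured compounds shown here, the steps that bear on it are an at least 2.7-fold lower number from compound 1 to compound 2 (0.44 log units; beyond the scatter) and an at least 4.5-fold lower number from compound 1 to compound 3 (0.65 log units; beyond the scatter), each placing a phenoxy or an anilino group on the aromatic carbon, while the exchange of one such group for the other, a 1.6-fold lower number from compound 2 to compound 3 (0.21 log units; within the scatter), stayed within the scatter. A further exchange of this kind is therefore expected to give no step beyond the scatter, a 1.2-fold higher number from compound 3 to compound 4 (0.07 log units; within the scatter). For compound 4 the estimate is 13000 nM, between 5000 nM and 35000 nM.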

Compound 4, half-maximal cytotoxic concentration: 13000 nM
For compound 4 middle estimate and measured number coincide at the digits printed; measured number inside the range.
By their numbers in this assay, from the lowest: compounds 3, 4 and 2 (each within the scatter of the next). At a limit, above all of these: compound 1.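

Benzoyl brings a carbonyl and no hydrogen-bond donor, yet it stays level with anilino and phenoxy on this aromatic carbon, with a 1.2-fold higher number from compound 3 to compound 4 (0.07 log units; within the scatter) and a 1.4-fold lower number from compound 2 to compound 4 (0.14 log units; within the scatter). The step from hydrogen, an at least 3.8-fold lower number from compound 1 to compound 4 (0.58 log units; beyond the scatter), now sets three different groups apart from hydrogen at this place. Compound 1 gives a limit and not a number: the limit of > 50000 nM in this assay, at which 1 of the 4 values shown sits.

The compounds shown leave open whether a smaller group here, such as methoxy, an amine or a carboxylic acid, would also lower the number. Going by these compounds, the effect of a longer chain also remains open.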